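Ring Nitrogen Enters the Ortho-Chloro Aryl Urea

The compounds below may be only part of what the source reports. "The series", "measured", "known", "first", "only" and "open" are said of these compounds alone.

Three ureas were measured in an assay on isolated protein for displacement of a labelled ligand from acyl-CoA:cholesterol acyltransferase (Oryctolagus cuniculus); on this read-out lower numbers stand for stronger inhibition and higher numbers for weaker inhibition:
compound 1, `CC(C)c1cccc(C(C)C)c1NC(=O)Nc1nc2ccccc2n1-c1ccccc1Cl`, gives 18 nM
compound 2, `CC(C)c1cccc(C(C)C)c1NC(=O)Nc1nc2ccccc2n1-c1ccc(Cl)cc1`, gives 280 nM
compound 3, `CC(C)c1cccc(C(C)C)c1NC(=O)Nc1nc2ccccc2n1-c1ccccc1C(F)(F)F`, gives 72 nM

Compound 3 sits second highest of the three numbers: a 3.9-fold lower number from compound 2 to compound 3 (0.59 log units; beyond the scatter), while a 4.0-fold higher number from compound 1 to compound 3 (0.60 log units; beyond the scatter). Compound 4, `CC(C)c1cccc(C(C)C)c1NC(=O)Nc1nc2ccccc2n1-c1ncccc1Cl`, differs from compound 3 by 3-chloropyridin-2-yl in place of 2-(trifluoromethyl)phenyl on an aromatic nitrogen. The closest measured guide is the chloro-for-trifluoromethyl comparison, where a 4.0-fold higher number from compound 1 to compound 3 (0.60 log units; beyond the scatter), so a return to chloro points toward a lower number. For the measured compounds named here, no measured step covers a ring nitrogen in this aryl group, so that part is uncertain. Compound 4 is therefore expected near 30 nM, between 10 nM and 100 nM. The expected step, a modest fall, is a 2.4-fold lower number from compound 3 to compound 4 (0.38 log units; beyond the scatter).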

Compound 4, half-maximal inhibitory concentration: 100 nM
Estimate against measurement, compound 4: 3.3-fold (0.52 log units) below; the range from low to high includes it.
By their numbers in this assay, from the lowest: compound 1; then compounds 3 and 4 (each within the scatter of the next); then compound 2.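

Adding a ring nitrogen to the aryl group while keeping the chlorine weakens inhibition, with a 5.6-fold higher number from compound 1 to compound 4 (0.74 log units; beyond the scatter) for this single change. The resulting 3-chloropyridin-2-yl group still compares well with 4-chlorophenyl, with a 2.8-fold lower number from compound 2 to compound 4 (0.45 log units; beyond the scatter) in its favour, and the step of a 1.4-fold higher number from compound 3 to compound 4 (0.14 log units; within the scatter) does not separate it from 2-(trifluoromethyl)phenyl. No measurement available here explains the effect of the ring nitrogen.

Going by these compounds, it remains open whether the ring nitrogen would have a similar effect with a methyl or methoxy group in place of the chlorine. Whether an amine would be tolerated there is also unknown.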